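Replacing the cyanobenzyl arm with carboxymethyl

This account rests on a few compounds, and the source may have more. Where it says the series, first, only, none or still open, it means among the compounds named here.

Compound 1 `CN(Cc1ccc(C#N)cc1)[C@@H]1CN[C@H](C(=O)N2CCSC2)C1`: 13.6 nM
Compound 2 `CC(C)N(Cc1ccc(C#N)cc1)[C@@H]1CN[C@H](C(=O)N2CCSC2)C1`: 12.5 nM
Compound 3 `N#Cc1ccc(CN(Cc2ccc(C#N)cc2)[C@@H]2CN[C@H](C(=O)N3CCSC3)C2)cc1`: 9.3 nM

All three were measured in an assay on a cell-free system (plasma) for inhibition of Dipeptidyl peptidase 4 (Rattus norvegicus), read by fluorescence; a higher number here means a weaker inhibitor, a lower number a stronger inhibitor. Compound 3 gives the lowest of the three numbers, but its separation from the others is small: a 1.5-fold lower number from compound 1 to compound 3 (0.17 log units; within the scatter) and a 1.3-fold lower number from compound 2 to compound 3 (0.13 log units; within the scatter), both within the scatter, as is a 1.1-fold lower number from compound 1 to compound 2 (0.04 log units; within the scatter).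

Compound 4 `N#Cc1ccc(CN(CC(=O)O)[C@@H]2CN[C@H](C(=O)N3CCSC3)C2)cc1` differs from compound 3 by carboxy in place of 4-cyanophenyl on a saturated chain carbon bound to an amine nitrogen. Among the measured compounds shown here, no measured step swaps in a carboxy at this place, so the expectation rests only on the observation that changes at the amine nitrogen among compounds 1, 2 and 3 stayed within the scatter. A modest weakening is estimated, a 2.4-fold higher number from compound 3 to compound 4 (0.37 log units; beyond the scatter), with wide uncertainty. Compound 4 is expected to give about 22 nM, between 6 nM and 80 nM.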

Compound 4, half-maximal inhibitory concentration: 16.3 nM
Compound 4: the middle estimate sits 1.3-fold (0.13 log units) above what was measured; measured number inside the range.
By their numbers in this assay, from the lowest: compounds 3, 2, 1 and 4 (each within the scatter of the next).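

On a saturated chain carbon bound to an amine nitrogen, carboxy, with no ring and one hydrogen-bond donor, can stand in place of 4-cyanophenyl with the change staying within the scatter in this assay (a 1.8-fold higher number from compound 3 to compound 4 (0.24 log units; within the scatter)). The same holds against the smaller groups (a 1.3-fold higher number from compound 2 to compound 4 (0.12 log units; within the scatter); a 1.2-fold higher number from compound 1 to compound 4 (0.08 log units; within the scatter)), so methyl, isopropyl, 4-cyanobenzyl and carboxymethyl on this amine nitrogen are not separated by any step beyond the scatter. No available evidence accounts for this tolerance.

As far as these compounds go, whether an amine, a longer chain ending in a carboxylic acid, or the methyl ester of compound 4 would also stay within the scatter remains open.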